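Replacing the Phenyl Group of Compound 3

A few compounds are considered here, and "the series" means these few. Any claim that something is new, unique, unknown or untested is made for them only; others in the source may bear on it.

In an ADME assay on HEp-2 cells (Homo sapiens) for cytotoxicity, read by MTT assay, with a stated time of 72 h (a higher number here means a weaker inhibitor, a lower number a stronger inhibitor), compound 3 `COc1cc(C2=C(c3ccccc3)C(O[SiH2]C(C)(C)C)CC2=O)cc(OC)c1OC` gives only a limit of the assay, > 100 ug/mL. Compound 2 `COc1ccc(C2=C(c3cc(OC)c(OC)c(OC)c3)C(=O)CC2O[SiH2]C(C)(C)C)cc1OC` also gives only a limit, > 100 ug/mL. Compound 1 `COc1ccc(OC)c(C2=C(c3cc(OC)c(OC)c(OC)c3)C(=O)CC2O[SiH2]C(C)(C)C)c1` alone gives a number, 19 ug/mL. Compound 4 `COCOc1cc(C2=C(c3cc(OC)c(OC)c(OC)c3)C(=O)CC2O[SiH2]C(C)(C)C)ccc1OC` differs from compound 3 by 4-methoxy-3-(methoxymethoxy)phenyl in place of phenyl on a double-bonded ring carbon: 4-methoxy-3-(methoxymethoxy)phenyl in place of phenyl. This group looks most like the 3,4-dimethoxyphenyl of compound 2. Within the data shown here, the steps that bear on it are an at least 5.2-fold higher number from compound 1 to compound 2 (0.72 log units; beyond the scatter) and an at least 5.2-fold higher number from compound 1 to compound 3 (0.72 log units; beyond the scatter), while a step that the two limits leave unreadable from compound 2 to compound 3 tells nothing. Compound 4 is therefore expected to stay weak, with no step beyond the scatter. The expected step is an at least 1.1-fold lower number from compound 3 to compound 4 (0.04 log units; that floor lies within the scatter). For compound 4 the estimated value is 90 ug/mL, with an expected range of 30 ug/mL to 150 ug/mL.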

Compound 4, half-maximal inhibitory concentration: 12 ug/mL
Compound 4: middle estimate off by 7.5-fold (0.88 log units), on the high side; measured number outside the range, below it.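

In this assay, 4-methoxy-3-(methoxymethoxy)phenyl gives an at least 8.3-fold lower number from compound 3 to compound 4 (0.92 log units; beyond the scatter), so a lower number at this double-bonded ring carbon is possible with more than the 2,5-dimethoxyphenyl of compound 1. The change at the chain alone matters too: methoxy in place of hydrogen gives an at least 8.3-fold lower number from compound 2 to compound 4 (0.92 log units; beyond the scatter). Compound 4 also matches compound 1 within the scatter, with a 1.6-fold lower number from compound 1 to compound 4 (0.20 log units; within the scatter).

Going by these compounds, the full size of the first two steps stays open, as each starts from a limit: the limit of > 100 ug/mL in this assay, at which 2 of the 4 values shown sit. Whether a hydroxy group or an amine in place of methoxymethoxy would keep this number also stays open.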